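This account rests on a few compounds, and the source may have more. Where it says the series, first, only, none or still open, it means among the compounds named here.

Measured so far:
compound 1 `Cn1c(=O)c(S(=O)(=O)c2ccc(F)cc2F)cc2cnc(Nc3ccc4[nH]c(C(=O)O)cc4c3)nc21` — 10000 nM
compound 2 `Cn1c(=O)c(S(=O)(=O)c2ccc(Cl)cc2)cc2cnc(Nc3cnc4ccccc4c3)nc21` — 15000 nM

In a functional assay on DU-145 cells (Homo sapiens) for inhibition, read by trypan blue exclusion, with a stated time of 72 h (a lower number here means a stronger inhibitor, a higher number a weaker inhibitor), compound 1 gives 10000 nM and compound 2 gives 15000 nM. Compound 1 has the lower of the two numbers, but the gap to compound 2 lies within the scatter, so neither compound can be called the stronger inhibitor; both sit at the weak end of what this assay resolves.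

Compound 3 `Cn1c(=O)c(S(=O)(=O)c2ccc(F)cc2F)cc2cnc(Nc3ccccn3)nc21` differs from compound 1 in one place: pyridin-2-yl in place of 2-carboxy-1H-indol-5-yl on a nitrogen on an aromatic ring. Among the measured compounds shown here, no step between measured compounds covers a change of this kind, so the expectation rests on the two weak values alone. Compound 1 already gives 10000 nM, and nothing in the data points to a gain, so a step toward a weaker inhibitor, or none beyond the scatter, is expected. Compound 3 is estimated at 15000 nM, range 5000 nM to 50000 nM, which means an expected step of a 1.5-fold higher number from compound 1 to compound 3 (0.18 log units; within the scatter).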

Compound 3, half-maximal inhibitory concentration: 75000 nM
Compound 3: middle estimate off by 5.0-fold (0.70 log units), on the low side, outside the stated range (above it).
By their numbers in this assay, from the lowest: compounds 1 and 2 (each within the scatter of the next); then compound 3.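

In this assay, the group on the nitrogen on the aromatic ring can move the number: pyridin-2-yl in place of 2-carboxy-1H-indol-5-yl gives a 7.5-fold higher number from compound 1 to compound 3 (0.88 log units; beyond the scatter), a step beyond the scatter that the two earlier values could not show. The change takes out 12 heavy atoms with 2 hydrogen-bond donors and puts in 6 heavy atoms with 0 donors, so size, ring count and donor count all change in this one pair. No measurement here bears on the reason for the step.

On these data alone, whether the carboxylic acid or the second ring carries the difference stays open; an indol-5-yl without the acid, or a pyridin-2-yl carrying one, on the same core would separate the two. Also open, as far as these compounds go, is whether any group on this nitrogen gives a clearly lower number than compound 1 at 10000 nM.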